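Trimming the Amide Substituent in a Disulfonamide Series

The source may report more compounds than this note shows. Statements on the series, on what has been measured and on what is new or still open speak of the compounds shown alone.

Compound 1 `CCN(CC)S(=O)(=O)c1ccc(S(=O)(=O)N2CCC[C@@H](C(=O)NC3CN(C(=O)OC(C)(C)C)C3)C2)cc1`: 1800 nM
Compound 2 `CCOC(=O)[C@@H]1CCCN(S(=O)(=O)c2ccc(S(=O)(=O)N(CC)CC)nc2)C1`: 8000 nM
Compound 3 `CCOC(=O)N1CCC[C@H](S(=O)(=O)c2ccc(S(=O)(=O)N(CC)CC)cc2)C1`: > 30000 nM

Three measured compounds share a bis-sulfonyl arrangement and are compared in a functional assay on BXPC-3 cells (Homo sapiens) for inhibition, read by MTT assay, with a stated time of 7 days; on this read-out higher numbers stand for weaker inhibition and lower numbers for stronger inhibition. Compound 1 gives 1800 nM, the lowest of the two numbers shown. Compound 2 gives 8000 nM, which stands beyond the usual scatter from the value of compound 1. Compound 3 gives > 30000 nM, which is a limit of this assay and not a number. For compound 3 the relevant observation is the limit of > 30000 nM in this assay, at which 1 of the 3 values shown sits.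

Compound 4 `CCN(CC)S(=O)(=O)c1ccc(S(=O)(=O)N2CCC[C@@H](C(=O)NC3COC3)C2)cc1` has not yet been measured in this assay . It differs from compound 1 in a single place: oxetan-3-yl in place of 1-(tert-butoxycarbonyl)azetidin-3-yl on an amide-type nitrogen. The change removes the 1-(tert-butoxycarbonyl)azetidin-3-yl group from the amide-type nitrogen and puts oxetan-3-yl there instead. Among the measured compounds shown here, no measured pair in this set isolates such a change, so the expectation rests on the structures alone. The step of a 2.8-fold higher number from compound 1 to compound 4 (0.44 log units; beyond the scatter) is expected to run toward a higher number, somewhat beyond the scatter. Compound 4 is therefore estimated at 5000 nM, within a range from 1500 nM to 20000 nM.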

Compound 4, half-maximal inhibitory concentration: 13800 nM
Beside the measured number, compound 4's estimate is 2.8-fold (0.44 log units) below it; the range from low to high includes it.
By their numbers in this assay, from the lowest: compound 1; then compounds 2 and 4 (each within the scatter of the next). At a limit, above all of these: compound 3.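

In this assay, among the compounds shown here, putting oxetan-3-yl in place of 1-(tert-butoxycarbonyl)azetidin-3-yl on the amide-type nitrogen gives a 7.7-fold higher number from compound 1 to compound 4 (0.88 log units; beyond the scatter), the only step in this set that isolates a change in one place. It shows that the read-out responds to the substituent at this nitrogen: in this single pair, the group of 11 heavy atoms goes with the lower number and the group of 4 heavy atoms with the higher one. Nothing in the information available explains this step.

The compounds shown leave open how a free azetidin-3-yl amine, a cyclobutyl group or a longer alkyl chain on the same nitrogen would read. They also leave open whether the tert-butoxycarbonyl group or the ring that carries it accounts for the step.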